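The source may report more compounds than this note shows. Statements on the series, on what has been measured and on what is new or still open speak of the compounds shown alone.

Compound 1 `Nc1sc(-c2ccc(Cl)cc2)c(-c2ccc(Cl)cc2)c1C(=O)N1CCCC1` carries a pyrrolidin-1-yl on a carbonyl carbon of the shared core. Among the compounds with values here, in a functional assay on A549 cells (Homo sapiens) for inhibition, read by sulforhodamine B assay, with a stated time of 72 h (a higher number here means a weaker inhibitor, a lower number a stronger inhibitor), compound 1 gives 890 nM, the lowest of the three numbers known. Compound 2 `CC(C)(C)NC(=O)c1c(N)sc(-c2ccc(Cl)cc2)c1-c1ccc(Cl)cc1` gives 8850 nM and compound 3 `Nc1sc(-c2ccc(Cl)cc2)c(-c2ccc(Cl)cc2)c1C(=O)NC1CCCC1` gives 6790 nM; the steps are a 9.9-fold higher number from compound 1 to compound 2 (1.00 log units; beyond the scatter) and a 7.6-fold higher number from compound 1 to compound 3 (0.88 log units; beyond the scatter), while between the two larger numbers there is a 1.3-fold lower number from compound 2 to compound 3 (0.12 log units; within the scatter). Compound 4 `Nc1sc(-c2ccc(Cl)cc2)c(-c2ccc(Cl)cc2)c1C(=O)N1CCC(=O)CC1=O` differs from compound 1 by 2,4-dioxopiperidin-1-yl in place of pyrrolidin-1-yl on a carbonyl carbon. Both measured steps that replaced the pyrrolidin-1-yl raised the number, though neither involved a 2,4-dioxopiperidin-1-yl, so their bearing is indirect. Compound 4 is therefore expected to show a higher number, with the step estimated as a 5.6-fold higher number from compound 1 to compound 4 (0.75 log units; beyond the scatter). The estimate for compound 4 is 5000 nM, within 1500 nM to 20000 nM.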

Compound 4, half-maximal inhibitory concentration: 4090 nM
Compound 4: middle estimate off by 1.2-fold (0.09 log units), on the high side; the range from low to high includes it.
By their numbers in this assay, from the lowest: compound 1; then compounds 4, 3 and 2 (each within the scatter of the next, the first and the last beyond it).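

In this assay, a ring bound through its nitrogen on the carbonyl carbon is not enough to keep the number low: the 2,4-dioxopiperidin-1-yl raises it (a 4.6-fold higher number from compound 1 to compound 4 (0.66 log units; beyond the scatter)), as the open-chain and cyclopentylamino replacements did. Compound 4 lies within the scatter of compound 3 (a 1.7-fold lower number from compound 3 to compound 4 (0.22 log units; within the scatter)), but not of compound 2 (a 2.2-fold lower number from compound 2 to compound 4 (0.34 log units; beyond the scatter)). Compound 1 thus remains the strongest of the four. As far as these compounds go, it stays open whether a plain piperidin-1-yl, without the two ring carbonyls, or a morpholin-4-yl would stay close to compound 1. Nothing at hand explains these steps.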